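The source may report more compounds than this note shows. Statements on the series, on what has been measured and on what is new or still open speak of the compounds shown alone.

The series shares one core, seen in compound 1 `O=C(C1CC12CCC2)N1CCc2nc(C#Cc3ccccc3)sc2C1`, and the members differ only in the group on the carbonyl carbon. In an assay on HEK293 cells for positive allosteric modulation of metabotropic glutamate receptor 5 (Homo sapiens), read by FLIPR, with a stated time of 1 h (on this read-out lower numbers stand for an effect already at smaller amounts and higher numbers for an effect only at larger amounts of compound), compound 1 gives 3.9 nM. Compound 2 `O=C(C1CCC1)N1CCc2nc(C#Cc3ccccc3)sc2C1` reaches only > 10000 nM in this assay, which is a limit of the assay rather than a number. Compound 3 `O=C(C1CC(F)C1)N1CCc2nc(C#Cc3ccccc3)sc2C1` gives 85 nM in this assay, which places it highest of the two numbers shown; the nearest is compound 1, with a 22-fold higher number from compound 1 to compound 3 (1.34 log units; beyond the scatter). The other two steps on the same carbonyl carbon are also large: an at least 2500-fold higher number from compound 1 to compound 2 (3.40 log units; beyond the scatter), and an at least 110-fold lower number from compound 2 to compound 3 (2.07 log units; beyond the scatter).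

Compound 4 `O=C(C1CCCCO1)N1CCc2nc(C#Cc3ccccc3)sc2C1` has not yet been measured in this assay. It differs from compound 3 by oxan-2-yl in place of 3-fluorocyclobutyl on a carbonyl carbon. All three measured steps bear on this change, since each replaces the group on the carbonyl carbon, and each was large, so a large step in either direction is possible here. The oxan-2-yl ring itself has no parallel among the measured compounds. Compound 4 is therefore expected to give a value near 300 nM in this assay, somewhere between 30 nM and 3000 nM. That estimate corresponds to an expected step of a 3.5-fold higher number from compound 3 to compound 4 (0.55 log units; beyond the scatter), with a real chance that this assay reports only a limit.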

Compound 4, half-maximal effective concentration: 320 nM
Beside the measured number, compound 4's estimate is 1.1-fold (0.03 log units) below it; measured number inside the range.
By their numbers in this assay, from the lowest: compound 1; then compound 3; then compound 4. At a limit, above all of these: compound 2.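

In this assay, oxan-2-yl on the carbonyl carbon, the only ring here with a hetero atom, gives a 3.8-fold higher number from compound 3 to compound 4 (0.58 log units; beyond the scatter), a modest step, and in place of cyclobutyl it gives an at least 31-fold lower number from compound 2 to compound 4 (1.49 log units; beyond the scatter). The figure for compound 2 in that comparison is a limit of the assay and not a number: the limit of > 10000 nM in this assay, at which 1 of the 4 values shown sits. The group on compound 1 has the same count of heavy atoms as oxan-2-yl, yet the change still brings an 82-fold higher number from compound 1 to compound 4 (1.91 log units; beyond the scatter), so among these compounds the count of heavy atoms alone does not set the number, and a ring with an oxygen in it does not match the group of compound 1, which has rings of carbon only.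

The compounds shown leave open whether the ring size or the ring oxygen of oxan-2-yl accounts for the difference from cyclobutyl, and a plain cyclohexyl group on the same carbonyl carbon would separate the two. They also leave open how an open chain, such as a methoxyethyl group, or a fluorine on the oxan-2-yl ring would read in this assay.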